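Would one more methoxy lift compound 3?

The compounds below may be only part of what the source reports. "The series", "measured", "known", "first", "only" and "open" are said of these compounds alone.

Measured in a functional assay on DWD cells (Homo sapiens) for inhibition, read by sulforhodamine B assay; a higher number here means a weaker inhibitor of growth, a lower number a stronger inhibitor of growth:
- compound 1 `COc1ccc(-c2ccc(-c3ccc(-c4nc5cc(C)ccc5[nH]4)cc3)cc2)cc1OC`: 1720 nM
- compound 2 `COc1cc(-c2ccc(-c3ccc(-c4nc5cc(C)ccc5[nH]4)cc3)cc2)cc(OC)c1OC`: 170 nM
- compound 3 `COc1ccc(-c2ccc(-c3ccc(-c4nc5ccccc5[nH]4)cc3)cc2)cc1OC`: 42100 nM

Compound 3 has the highest number of the three, which makes it the weakest inhibitor of growth in this set. Replacing the methyl of compound 1 with hydrogen gives a 24-fold higher number from compound 1 to compound 3 (1.39 log units; beyond the scatter).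

Compound 4 `COc1cc(-c2ccc(-c3ccc(-c4nc5ccccc5[nH]4)cc3)cc2)cc(OC)c1OC` is compound 3 with a single change, methoxy in place of hydrogen on an aromatic carbon.

The same swap has been measured only once, on the methyl-bearing pair, where it gave a 10-fold lower number from compound 1 to compound 2 (1.01 log units; beyond the scatter). Compound 3 lacks that methyl, so the swap may not carry over exactly, and one pair is thin evidence. Even so, a large step toward a lower number is expected, similar in size to the one seen for compound 2. The estimated step is a 10-fold lower number from compound 3 to compound 4 (1.00 log units; beyond the scatter). The estimate for compound 4 is 4200 nM, expected to fall between 1000 nM and 17000 nM.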

Compound 4, concentration for 50% growth inhibition: 8010 nM
For compound 4 the middle estimate is 1.9-fold (0.28 log units) below the measured one, and the stated range covers the measured number.
By their numbers in this assay, from the lowest: compound 2; then compound 1; then compound 4; then compound 3.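

In this assay, adding the methoxy also lowers the number on the core without the methyl, giving a 5.3-fold lower number from compound 3 to compound 4 (0.72 log units; beyond the scatter), so the gain no longer rests on a single pair of compounds. Set side by side, the two methoxy steps agree: the same change on two cores in this assay, a 10-fold lower number (1.01 log units; beyond the scatter) from compound 1 to compound 2 and a 5.3-fold lower number (0.72 log units; beyond the scatter) from compound 3 to compound 4, 1.9-fold (0.28 log units) apart, within the scatter of two such steps

The methyl now has a second test as well, with a 47-fold higher number from compound 2 to compound 4 (1.67 log units; beyond the scatter), and the loss on removing it holds whether or not the extra methoxy is present: the same change on two cores in this assay, a 24-fold higher number (1.39 log units; beyond the scatter) from compound 1 to compound 3 and a 47-fold higher number (1.67 log units; beyond the scatter) from compound 2 to compound 4, 1.9-fold (0.28 log units) apart, within the scatter of two such steps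

The four compounds leave open whether this position needs a methoxy in particular, or whether an ethoxy, a hydroxyl or an amine there would lower the number as well. They also cannot show whether another small group, such as chlorine or ethyl, could stand in for the methyl.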